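The source may report more compounds than this note shows. Statements on the series, on what has been measured and on what is new or still open speak of the compounds shown alone.

In a functional assay on BaF3 cells (Mus musculus) for inhibition, read by CCK-8 assay, with a stated time of 72 h (on this read-out lower numbers stand for stronger inhibition of growth and higher numbers for weaker inhibition of growth), compound 1 `Cc1ccc(NC(=O)Nc2ccc(Oc3cc(N)ncn3)cc2)cc1C(F)(F)F` reaches only a limit of the assay, > 10000 nM. Going by the values given here, compound 2 `Cc1ccc(NC(=O)Nc2ccc(Oc3cc(N4CCNC[C@H]4C)ncn3)cc2)cc1C(F)(F)F` gives 9670 nM, the only true number so far. Among the compounds with values here, the one measured step, an at least 1.0-fold lower number from compound 1 to compound 2 (0.01 log units; that floor lies within the scatter), places 2-methylpiperazin-1-yl in place of amino on an aromatic carbon, and it lies within the scatter. Compound 3 `Cc1ccc(NC(=O)Nc2ccc(Oc3cc(N4CCNC[C@@H]4C)ncn3)cc2)cc1C(F)(F)F` keeps that group and differs from compound 2 in configuration alone: the two compounds have the same atoms and bonds and differ only in configuration as drawn: 1 of 1 stereo elements differ; a stereocentre at a saturated ring carbon is drawn R in compound 2 and S in compound 3. Within the data shown here, the step from compound 1 does not test configuration, so it bears on this change only indirectly, and no measured step shows the effect of the stereocentre. No change beyond the scatter is therefore expected in this assay, in either direction. The expected step is a 1.1-fold lower number from compound 2 to compound 3 (0.03 log units; within the scatter). For compound 3 the estimate is 9000 nM, with an expected range from 4000 nM to 10000 nM.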

Compound 3, concentration for 50% growth inhibition: 8120 nM
The estimate for compound 3 lay 1.1-fold (0.04 log units) above the measured number, and the stated range covers the measured number.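

Changing the saturated ring carbon from R as drawn to S as drawn gives a 1.2-fold lower number from compound 2 to compound 3 (0.08 log units; within the scatter) in this assay, so this first test of the stereocentre does not separate the two configurations. That step speaks to the stereocentre alone because of what the pair shares: the fact that compounds 2 and 3 differ only in the configuration as drawn. With the S form of the 2-methylpiperazin-1-yl group, the change from amino gives an at least 1.2-fold lower number from compound 1 to compound 3 (0.09 log units; that floor lies within the scatter), and this step remains only a floor because of where it starts: the limit of > 10000 nM in this assay, at which 1 of the 3 values shown sits.

The compounds shown leave open whether another group at this place on the shared core, such as a morpholine, an unsubstituted piperazine or a longer chain ending in an amine, would lower the number beyond the scatter. Going by these compounds, it also remains open whether the configuration would matter in a compound with a much lower number.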